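A few compounds are considered here, and "the series" means these few. Any claim that something is new, unique, unknown or untested is made for them only; others in the source may bear on it.

The compounds share the core seen in compound 1 `Cc1nsc2[nH]cnc12`. In a functional assay on KB cells (Homo sapiens) for antiproliferative activity (on this read-out lower numbers stand for stronger inhibition and higher numbers for weaker inhibition), compound 1 gives 20000 nM. Compound 2 `Cc1nsc2c1ncn2[C@H]1C[C@H](O)[C@@H](CO)O1` extends that core. In this assay compound 2 reaches only the limit > 100000 nM, not a number. Compound 3 `CSc1nc2c(C)nsc2n1[C@H]1C[C@H](O)[C@@H](CO)O1` carries methylsulfanyl in place of hydrogen on an aromatic carbon. In this assay compound 3 likewise reaches only the limit > 100000 nM, not a number. Compound 3 therefore stands at the top of the numbers shown, and the step that the two limits leave unreadable from compound 2 to compound 3 cannot be read because both of its ends sit at the limit of > 100000 nM in this assay, at which 2 of the 3 values shown sit. Compound 4 `CSc1nc2cnsc2n1[C@H]1C[C@H](O)[C@@H](CO)O1` differs from compound 3 by hydrogen in place of methyl on an aromatic carbon. Within the data shown here, no measured step bears on this change, and the single measured step is unreadable in size. Since compound 3 sits at the limit of > 100000 nM in this assay, at which 2 of the 3 values shown sit, compound 4 is expected to remain near that limit, with a step of a number no higher from compound 3 to compound 4 (the limit leaves the size open) that cannot be separated from none. The estimate for compound 4 in this assay is 100000 nM, between 40000 nM and 250000 nM.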

Compound 4, half-maximal inhibitory concentration: > 100000 nM
Compound 4 gave a limit, no number; the forecaster's own chance of this, stated with the estimate: 75%; the middle value lies on the limit itself.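

No new step can be read between compound 3 and compound 4, because both compounds give a limit rather than a number: the limit of > 100000 nM in this assay, at which 3 of the 4 values shown sit.

The compounds shown leave open whether hydrogen in place of methyl on an aromatic carbon changes the antiproliferative activity at all.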